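Methoxy placement on the fused ring of compound 2

The compounds below may be only part of what the source reports. "The series", "measured", "known", "first", "only" and "open" are said of these compounds alone.

Read-out for the series: a functional assay on HT-29 cells (Homo sapiens) for cytotoxicity, read by sulforhodamine B assay, with a stated time of 48 h; a higher number here means a weaker inhibitor of growth, a lower number a stronger inhibitor of growth.
Compound 1 `COC(=O)c1[nH]c2ccccc2c1C(=O)c1cc(OC)c(OC)c(OC)c1N` gives 2380 nM in this assay.
Compound 2 `COc1cc(Cc2c[nH]c3ccccc23)c(N)c(OC)c1OC` gives only a limit, > 100000 nM, in this assay.
Compound 3 `COc1ccc2c(Cc3cc(OC)c(OC)c(OC)c3N)c[nH]c2c1` gives 74800 nM in this assay.

Compound 2 stands at the limit of > 100000 nM in this assay, at which 1 of the 3 values shown sits; no number is known for it, so its place among the three is only a bound. Compound 1 differs from compound 2 in more than one place, and its value is simply the lower of the two. Compound 4 `COc1cc(Cc2c[nH]c3c(OC)cccc23)c(N)c(OC)c1OC` is the unmeasured member; it differs from compound 2 by methoxy in place of hydrogen on an aromatic carbon. The one measured step of the same kind is an at least 1.3-fold lower number from compound 2 to compound 3 (0.12 log units; that floor lies within the scatter), which reaches no further than the scatter floor, so a methoxy entering the fused ring has so far shown no clear effect. For compound 4 the change is therefore expected to leave the number near the limit, the expected step being an at least 1.1-fold lower number from compound 2 to compound 4 (0.04 log units; that floor lies within the scatter) because an at least 1.3-fold lower number from compound 2 to compound 3 (0.12 log units; that floor lies within the scatter) gave so little. Compound 4 is estimated at 90000 nM, within 30000 nM to 250000 nM, with a fair chance that only a limit is reported again.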

Compound 4, concentration for 50% growth inhibition: "not active" (no number reported)
No number was reported for compound 4; there is nothing to compare the estimate with.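

In this assay, among these compounds, compound 4 is reported as not active, without a number, so no step from compound 2 to compound 4 can be read. Compound 2 itself gives only a limit, > 100000 nM. The compounds shown leave open whether a methoxy on the fused ring changes growth inhibition at all, and whether its place there matters.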